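The source may hold more compounds than are shown below. What is called first, only, known or untested is meant among the compounds shown, and "the series" means these compounds.

Measured compounds

compound 1 `COc1cccc(C(=O)Nc2ccc(Cl)cc2CN2C(=O)c3ccccc3C2=O)c1` — < 1000 nM
compound 2 `O=C(Nc1ccc(Cl)cc1CN1C(=O)c2ccccc2C1=O)c1ccccc1C(F)(F)F` — < 1000 nM

In an assay on CHO cells for positive allosteric modulation of metabotropic glutamate receptor 5 (Rattus norvegicus), read by FLIPR (on this read-out higher numbers stand for an effect only at larger amounts of compound and lower numbers for an effect already at smaller amounts), compound 1 gives < 1000 nM, which is a limit of the assay and not a number. In this assay compound 2 gives < 1000 nM, again a limit rather than a number. For the measured compounds named here, the single step between measured compounds, a step that the two limits leave unreadable from compound 1 to compound 2, is consequently of unreadable size, since both values sit at the limit of < 1000 nM in this assay, at which 2 of the 2 values shown sit. Compound 2 therefore stands at the limit and nowhere more exact on the numbers shown.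

Compound 3 `O=C(Nc1ccc(Cl)cc1CN1C(=O)c2ccccc2C1=O)C1CCCCC1` has not been measured in this assay. It differs from compound 2 by cyclohexyl in place of 2-(trifluoromethyl)phenyl on a carbonyl carbon. Going by the values given here, no measured step bears on a change of this kind: the only recorded step, a step that the two limits leave unreadable from compound 1 to compound 2, swaps one six-membered aromatic ring for another and is itself unreadable. The expectation for compound 3 in this assay thus rests on nothing firmer than two limits. Compound 3 is estimated at 600 nM, with a range from 100 nM to 3000 nM. The expected step is a step that the limit leaves unreadable from compound 2 to compound 3, with a real chance that only a limit is reported again.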

Compound 3, half-maximal effective concentration: < 1000 nM
Compound 3 ended at the assay's limit; the forecaster's own chance of this, stated with the estimate: 55%; the middle value does not contradict the limit.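

No step among compound 1, compound 2 and compound 3 can be read in this assay, since each result is a limit and not a number: the limit of < 1000 nM in this assay, at which 3 of the 3 values shown sit.

Still open, on these data alone, is how far each compound lies from that limit, and whether 3-methoxyphenyl, 2-(trifluoromethyl)phenyl and cyclohexyl on a carbonyl carbon differ at all.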